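Moving the pyridine nitrogen on an inactive F508del corrector

This account rests on a few compounds, and the source may have more. Where it says the series, first, only, none or still open, it means among the compounds named here.

Of the compounds shown here, three sharing one core have been tested in an assay on A549 cells with Cystic fibrosis transmembrane conductance regulator variant F508del (Homo sapiens) as the target, read by fluorescence, with a stated time of 25 min; a lower number here means a smaller maximal response, a higher number a larger maximal response. Compound 1 `OC1CCCN(c2nc(-c3ccccn3)nc3c2CN(Cc2ccccc2)CC3)C1` gives 30.6% in this assay. Compound 2 `NC(=O)CN1CCN(c2nc(-c3ccccn3)nc3c2CN(Cc2ccccc2)CC3)CC1` is reported in this assay as "not active" (no number reported). Compound 3 `CN1CCN(CCCNc2nc(-c3ccccn3)nc3c2CN(Cc2ccccc2)CC3)CC1` is likewise reported in this assay as "not active" (no number reported), so no number stands for it; it is one of two entries without a single value, and it cannot be ranked against compound 1. Compound 4 `CN1CCN(CCCNc2nc(-c3cccnc3)nc3c2CN(Cc2ccccc2)CC3)CC1` differs from compound 3 only in the place described by pyridin-3-yl in place of pyridin-2-yl on an aromatic carbon. Within the data shown here, no measured pair shows this kind of change, so its effect in this assay is unknown; with compound 3 inactive, any shift beyond the usual scatter is expected to be small, and a low maximal response is expected for compound 4, estimated at 12% within 0% to 35%.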

Compound 4, largest response reached (Emax), in percent of the reference or control that the assay uses: "not active" (no number reported)
No number was reported for compound 4, and the estimate cannot be compared.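

In this assay compound 3 and compound 4 are both reported as not active, so no step can be read between them, and nothing at hand explains this result. From the compounds shown here alone, what stays open is whether pyridin-3-yl in place of pyridin-2-yl changes the response in a compound that gives a measurable one.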